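The source may report more compounds than this note shows. Statements on the series, on what has been measured and on what is new or still open speak of the compounds shown alone.

Three compounds share one core and differ only in the halogen pattern of the phenyl ring attached to an amide-type nitrogen. Compound 1 `Cc1nc(C(NC(=O)C(=O)Nc2ccc(Cl)cc2)C2CCCCN2)sc1CO` carries a 4-chlorophenyl group, compound 2 `Cc1nc(C(NC(=O)C(=O)Nc2ccc(Cl)c(F)c2)C2CCCCN2)sc1CO` a 4-chloro-3-fluorophenyl group, and compound 3 `Cc1nc(C(NC(=O)C(=O)Nc2ccc(F)cc2)C2CCCCN2)sc1CO` a 4-fluorophenyl group. All three were tested in an ADME assay on MT2 cells (Homo sapiens) for cytotoxicity, read by XTT assay, with a stated time of 4 days; on this read-out lower numbers stand for higher toxicity in this test and higher numbers for lower toxicity in this test. In this assay compound 1 reaches only a limit of the test, > 108000 nM. In this assay compound 2 gives 77800 nM. In this assay compound 3 also reaches only a limit, > 113000 nM.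

Compound 2 differs from compound 1 by fluoro in place of hydrogen on an aromatic carbon, and this change gave an at least 1.3-fold lower number from compound 1 to compound 2 (0.14 log units; that floor lies within the scatter). Compound 3 differs from compound 1 by fluoro in place of chloro on an aromatic carbon; the step that the two limits leave unreadable from compound 1 to compound 3 cannot be sized because the limit of > 108000 nM in this assay, at which 1 of the 3 values shown sits, and the limit of > 113000 nM in this assay, at which 1 of the 3 values shown sits, are both limits rather than numbers. From compound 2 to compound 3 the data show an at least 1.4-fold higher number from compound 2 to compound 3 (0.16 log units; that floor lies within the scatter).

Compound 4 `Cc1nc(C(NC(=O)C(=O)Nc2ccc(F)cc2F)C2CCCCN2)sc1CO` has not been measured yet. It differs from compound 3 by fluoro in place of hydrogen on an aromatic carbon. This is the same kind of change as that from compound 1 to compound 2, but not the same: in compound 2 the entering fluoro sits ortho to a chloro group and meta to a large group, whereas in compound 4 it sits ortho to a large group and meta to a fluoro group. Since the earlier fluoro addition gave an at least 1.3-fold lower number from compound 1 to compound 2 (0.14 log units; that floor lies within the scatter), a step lying within the usual scatter, a similarly small step is expected here, estimated as an at least 1.1-fold lower number from compound 3 to compound 4 (0.05 log units; that floor lies within the scatter). Compound 4 is therefore expected to give about 100000 nM in this assay, estimated to lie between 45000 nM and 200000 nM.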

Compound 4, half-maximal cytotoxic concentration: > 110000 nM
Compound 4: no number, only a limit; the forecaster's own chance of this, stated with the estimate: 50%; middle value at least 1.1-fold (0.04 log units) away from the limit.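

In this assay compound 4 reaches only a limit of the test, > 110000 nM. The steps from compound 3 to compound 4 and from compound 1 to compound 4 cannot be read, because compound 1, compound 3 and compound 4 all end at limits rather than numbers: the limit of > 110000 nM in this assay, at which 1 of the 4 values shown sits.

Among these compounds, the only new step that can be read is an at least 1.4-fold higher number from compound 2 to compound 4 (0.15 log units; that floor lies within the scatter), and it swaps the whole 4-chloro-3-fluorophenyl group for 2,4-difluorophenyl, so it does not isolate the effect of one added fluoro. The result therefore shows that adding a fluoro to compound 3 still leaves compound 4 at a limit, but it does not show whether the small step seen from compound 1 to compound 2 carries over to this second ring.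

The compounds shown leave open how far compound 1, compound 3 and compound 4 lie past their limits, so no order among them can be given. They also leave open what an amine or a carboxylic acid would do in place of the fluoro on this ring, where a readable number might replace a limit.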